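Replacing the piperidinyl sulfonamide of a potent amide inhibitor

The source may report more compounds than this note shows. Statements on the series, on what has been measured and on what is new or still open speak of the compounds shown alone.

Measured compounds:
compound 1 `O=C(NCc1ccc(S(=O)(=O)N2CCCCC2)cc1)c1cc2ccncc2[nH]1`, 1000 nM
compound 2 `O=C(NCc1ccc(S(=O)(=O)N2CCCCC2)cc1)c1cnc2nccn2c1`, 3 nM
compound 3 `O=C(NCc1ccc(S(=O)(=O)N2CCCCC2)cc1)c1ccn2ccnc2c1`, 1800 nM

In an assay for inhibition of Nicotinamide phosphoribosyltransferase (Homo sapiens), read by mass spectrometry, with stated times of 15 min and 30 min (a higher number here means a weaker inhibitor, a lower number a stronger inhibitor), compound 2 gives 3 nM, the lowest number of the three. The steps to it are large: a 330-fold lower number from compound 1 to compound 2 (2.52 log units; beyond the scatter) and a 600-fold higher number from compound 2 to compound 3 (2.78 log units; beyond the scatter), both beyond the scatter, while a 1.8-fold higher number from compound 1 to compound 3 (0.26 log units; within the scatter) stays within it. All three measured steps exchange the two-ring group on the carbonyl carbon; none touches the other end of the molecule.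

Compound 4 `O=C(NCc1ccc(S(=O)(=O)c2cccc(C(F)(F)F)c2)cc1)c1cnc2nccn2c1` keeps the carbonyl-side group of compound 2 and changes only the sulfonyl end: 3-(trifluoromethyl)phenyl in place of piperidin-1-yl on a sulfonyl sulfur. For the measured compounds named here, no measured step bears on this position, so the expectation rests on compound 2 alone, with 3 nM as the anchor and a wider range to cover the unknown. The number for compound 4 in this assay is expected to change little, a 1.7-fold higher number from compound 2 to compound 4 (0.22 log units; within the scatter), within the scatter or near it. Compound 4 is therefore estimated at 5 nM, in the range 1.5 nM to 20 nM.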

Compound 4, half-maximal inhibitory concentration: 1 nM
Beside the measured number, compound 4's estimate is 5.0-fold (0.70 log units) above it; the measured number lies below the stated range.
By their numbers in this assay, from the lowest: compound 4; then compound 2; then compounds 1 and 3 (each within the scatter of the next).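

this assay now has a measured step at the sulfonyl end: with 3-(trifluoromethyl)phenyl in place of piperidin-1-yl on a sulfonyl sulfur, the result is a 3.0-fold lower number from compound 2 to compound 4 (0.48 log units; beyond the scatter), a modest gain from an already low number. The earlier compounds shown here all carried piperidin-1-yl and differed only on the carbonyl side, so they could not show that this end can take a six-membered aromatic ring of carbon only, with 10 heavy atoms against 6, and lose nothing. Nothing shown here explains why the number falls.

This single step cannot separate the part played by the phenyl ring from that of the trifluoromethyl group, so plain phenyl would be the telling comparison. Also open, going by these compounds, is how morpholine or a short alkyl chain on the sulfonyl sulfur would compare, and whether the same exchange would give a similar step with the carbonyl-side groups of compound 1 or compound 3.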